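Chloro addition on the shared core: two benzyl series

The source may report more compounds than this note shows. Statements on the series, on what has been measured and on what is new or still open speak of the compounds shown alone.

Measured compounds:
Compound 1 `ClCc1ccccc1Cn1cnc2c(Cl)nc(Cl)nc21` — in a functional assay on HOP-62 cells (Homo sapiens) for cytotoxicity, read by sulforhodamine B assay, with a stated time of 48 h (on this read-out lower numbers stand for stronger inhibition of growth and higher numbers for weaker inhibition of growth), compound 1 gives 3630 nM.
Compound 2 `ClCc1ccccc1Cn1cnc2c(Cl)ncnc21` — in this assay compound 2 gives 6020 nM.
Compound 3 `ClCc1cccc(Cn2cnc3ncnc(Cl)c32)c1` — in this assay compound 3 gives 3980 nM.

Compound 2 and compound 1 differ in one place: chloro in place of hydrogen on an aromatic carbon. In this assay this gave a 1.7-fold lower number from compound 2 to compound 1 (0.22 log units; within the scatter), a step that does not leave the usual scatter. Compound 3 shares its atoms with compound 2 but joins them differently; the difference between the two cores is not broken down here. Against compound 1 and compound 2, compound 3 stands within the scatter of both.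

Compound 4 `ClCc1cccc(Cn2cnc3nc(Cl)nc(Cl)c32)c1` is not yet measured. Its difference from compound 3 is chloro in place of hydrogen on an aromatic carbon, the same change that carried compound 2 to compound 1. Among the measured compounds shown here, with only one earlier example of this change, and that one within the scatter, the expectation for the step from compound 3 to compound 4 in this assay rests on it alone and is set at a 1.6-fold lower number from compound 3 to compound 4 (0.20 log units; within the scatter), because compound 2 to compound 1 gave a 1.7-fold lower number from compound 2 to compound 1 (0.22 log units; within the scatter). Compound 4 is therefore estimated at 2500 nM in this assay, with a range from 1200 nM to 5500 nM.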

Compound 4, concentration for total growth inhibition: 3630 nM
For compound 4 the middle estimate is 1.5-fold (0.16 log units) below the measured one; measured number inside the range.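

In this assay, chloro in place of hydrogen on an aromatic carbon gave a 1.1-fold lower number from compound 3 to compound 4 (0.04 log units; within the scatter), and set beside the earlier case the change reads the same on both cores: the same change on two cores in this assay, a 1.7-fold lower number (0.22 log units; within the scatter) from compound 2 to compound 1 and a 1.1-fold lower number (0.04 log units; within the scatter) from compound 3 to compound 4, 1.5-fold (0.18 log units) apart, within the scatter of two such steps. Among the compounds shown here, both steps stay inside the scatter, so the agreement shows only that this change, placed between two ring nitrogen atoms, does not move the number out of the scatter on either core, not that a real shift of the same size and direction is carried from one core to the other. Two cores are also a narrow base, and they give no rule for any other core in the series.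

Open, going by these compounds, is whether an amine, a methoxy group or a longer chain at that same place, between two ring nitrogen atoms, would take the number beyond the scatter on either core. On these data alone, whether the chloro change reads alike in other cell lines stays open as well.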